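Pyrazole for thiophene on the benzyl arm

The source may report more compounds than this note shows. Statements on the series, on what has been measured and on what is new or still open speak of the compounds shown alone.

Compound 3 `Cc1cc(C)c(NC(=O)N(Cc2ccc(-c3ccsc3)cc2)C2CCCCCC2)c(C)c1` gives 0.51 mg/kg in a functional assay on a cell-free system (plasma) with sterol O-acyltransferase, Soat (Rattus norvegicus) as the target (on this read-out higher numbers stand for an effect only at larger amounts of compound and lower numbers for an effect already at smaller amounts), the highest of the two numbers recorded there, though within the scatter of compound 2 `Cc1cc(C)c(NC(=O)N(Cc2ccc(-c3cccs3)cc2)C2CCCCCC2)c(C)c1`, which gives 0.28 mg/kg. Compound 1 `Cc1cc(C)c(NC(=O)N(Cc2ccc(N3CCN(C)CC3)cc2)C2CCCCCC2)c(C)c1` reaches only a limit of this assay, > 1 mg/kg. Compound 4 `Cc1cc(C)c(NC(=O)N(Cc2ccc(-c3cc[nH]n3)cc2)C2CCCCCC2)c(C)c1` differs from compound 3 in one place: 1H-pyrazol-3-yl in place of thiophen-3-yl on an aromatic carbon. Going by the values given here, no measured step exchanges one five-membered ring for another of different composition. The closest, a 1.8-fold higher number from compound 2 to compound 3 (0.26 log units; within the scatter), stays within the scatter, while an at least 3.5-fold lower number from compound 1 to compound 2 (0.55 log units; beyond the scatter) and an at least 1.9-fold lower number from compound 1 to compound 3 (0.29 log units; that floor lies within the scatter) concern another group and rest on a limit (the limit of > 1 mg/kg in this assay, at which 1 of the 3 values shown sits). For compound 4 the expected step is a 1.4-fold higher number from compound 3 to compound 4 (0.14 log units; within the scatter), at most modest. The estimate for compound 4 is 0.7 mg/kg, with a range from 0.3 mg/kg to 2 mg/kg.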

Compound 4, dose for half-maximal effect: > 1 mg/kg
Compound 4: only a limit was reported; the forecaster's own chance of this, stated with the estimate: 25%; middle value at least 1.4-fold (0.15 log units) away from the limit.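

At this position, changing one five-membered aromatic ring for another of different composition now shifts the read-out of this assay beyond the scatter, with an at least 3.5-fold higher number from compound 2 to compound 4 (0.55 log units; beyond the scatter) against the thiophen-2-yl ring. Against the thiophen-3-yl ring, an at least 1.9-fold higher number from compound 3 to compound 4 (0.29 log units; that floor lies within the scatter) has a floor that stays within the scatter. Compound 4 and compound 1 both stand at a limit, so the step between them cannot be read: the limit of > 1 mg/kg in this assay, at which 2 of the 4 values shown sit.

The compounds shown leave open whether the hydrogen-bond donor of the 1H-pyrazol-3-yl ring matters here, and where a furan or a phenyl ring would fall at this position.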